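Swapping cyclohexyl for 1H-pyrazol-5-yl: what to expect

This account rests on a few compounds, and the source may have more. Where it says the series, first, only, none or still open, it means among the compounds named here.

Measured in a toxicity assay on THP-1 cells (Homo sapiens) for inhibition; on this read-out lower numbers stand for higher toxicity in this test and higher numbers for lower toxicity in this test:
Compound 1 `COc1ccc(-c2cnc(NC(=O)c3cccc(Cl)c3)n2C)cc1`: > 28000 nM
Compound 2 `COc1ccc(-c2cnc(NC(=O)C3CCCCC3)n2C)cc1`: > 100000 nM

Both entries are limits of the assay, not numbers. Compound 2 has only a limit, > 100000 nM, and no number.

Compound 3 `COc1ccc(-c2cnc(NC(=O)c3ccn[nH]3)n2C)cc1` has not yet been measured. It shares the core of compound 2 and differs in one group: 1H-pyrazol-5-yl in place of cyclohexyl on a carbonyl carbon. For the measured compounds named here, only one measured step bears on this change, and it also exchanges the group on the carbonyl carbon: a step that the two limits leave unreadable from compound 1 to compound 2. Its size cannot be read, so it offers no measured size to carry over to compound 3. With neither compound giving a number, the expectation in this assay is for no step beyond the usual scatter, in either direction, and another limit is a likely result.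

The expected step is an at least 1.4-fold lower number from compound 2 to compound 3 (0.15 log units; that floor lies within the scatter). For compound 3 the estimate is 70000 nM, with an expected range from 25000 nM to 200000 nM.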

Compound 3, half-maximal cytotoxic concentration: > 100000 nM
Compound 3 was reported as a limit; the forecaster's own chance of this, stated with the estimate: 75%; middle value at least 1.4-fold (0.15 log units) from the limit.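

In this assay compound 3 gives > 100000 nM as a limit of the assay and not a number. For the compounds shown here, compound 1 and compound 2 also have only limits, so no step among the three compounds can be read. The compounds shown leave open whether the group on the carbonyl carbon changes the result in this assay at all.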